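This account rests on a few compounds, and the source may have more. Where it says the series, first, only, none or still open, it means among the compounds named here.

Series notes. Compound 1 `COc1ccc(-n2cc3nc(-c4ccccc4)nc(N)c3n2)cc1` is the reference point. Going by the values given here, in an assay on CHO cells for displacement of a labelled ligand from adenosine receptor A1 (Homo sapiens), read by scintillation counting, with a stated time of 120 min, tested at 1 uM (on this read-out lower numbers stand for less inhibition and higher numbers for more inhibition at the one concentration tested (going by the name of the read-out)), compound 1 gives 12%, the higher of the two numbers measured so far. Among the compounds with values here, compound 2 `COc1ccc(-n2cc3nc(-c4ccccc4)nc(NC(C)=O)c3n2)cc1` carries an acetyl in place of hydrogen on a nitrogen on an aromatic ring; in this assay compound 2 gives 1%, and the step of a number 11 percentage points lower from compound 1 to compound 2 (beyond the scatter) is the only measured change in the set. Compound 3 `COc1ccc(-n2cc3nc(C)nc(N)c3n2)cc1` has not yet been measured. Its difference from compound 1 is methyl in place of phenyl on an aromatic carbon, a methyl in place of phenyl on an aromatic carbon of a six-membered aromatic ring with 2 nitrogen, between two ring nitrogen atoms. Within the data shown here, no measured step concerns this position; the one known step, a number 11 percentage points lower from compound 1 to compound 2 (beyond the scatter), concerns the nitrogen bearing the acetyl and gives no direct guide to the size of the present change. With compound 1 already low in this assay, there is little room downward and no evidence for a rise. The expectation for compound 3 is therefore a step of about a number 6 percentage points lower from compound 1 to compound 3 (within the scatter), within the scatter. Compound 3 is estimated at 6% in this assay, with a range from 0% to 20%.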

Compound 3, a percentage reported as inhibition, at one concentration (the size of the read-out at that concentration, not a potency): 30%
Compound 3: middle estimate off by 24 percentage points, on the low side; measured number above the stated range.
By their numbers in this assay, from the lowest: compound 2; then compound 1; then compound 3.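

In this assay, the aromatic carbon between two ring nitrogen atoms proves responsive to substitution, and phenyl is not required there for the read-out: replacing it with methyl gives a rise, a number 18 percentage points higher from compound 1 to compound 3 (beyond the scatter), which lies beyond the usual scatter. Going by these compounds alone, until now the only measured step was on the nitrogen bearing the acetyl and ran downward, a number 11 percentage points lower from compound 1 to compound 2 (beyond the scatter), so this is the first change in the set that raises the number and the first information on the position carrying the phenyl. Nothing on hand accounts for the rise, so the exchange of phenyl for methyl stands as an observation only.

Only phenyl and methyl are shown on this carbon, so it remains open whether a longer chain such as propyl, a saturated ring such as cyclohexyl, or an amine there would take the number further up or back down. On these data alone, it also remains open whether an acetyl on the amino nitrogen would lower the number with methyl on this carbon as it does with phenyl.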